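Swapping 3-chlorophenyl for 4-hydroxyphenyl on a shared core

This account rests on a few compounds, and the source may have more. Where it says the series, first, only, none or still open, it means among the compounds named here.

In a functional assay on HepG2 cells (Homo sapiens) for antiproliferative activity, read by MTT assay, with a stated time of 24 h (a higher number here means a weaker inhibitor, a lower number a stronger inhibitor), compound 1 (`COc1ccc(C(=O)/C=C/c2cccc([N+](=O)[O-])c2)c2c1C=CC(C)(C)O2`) gives 2830 nM and compound 2 (`COc1ccc(C(=O)/C=C/c2ccccn2)c2c1C=CC(C)(C)O2`) gives 5760 nM as measured values. Compound 3 (`COc1ccc(C(=O)/C=C/c2cccc(Cl)c2)c2c1C=CC(C)(C)O2`) gives > 10000 nM as its reading, which is a limit and not a number. Compound 4 (`COc1ccc(C(=O)/C=C/c2ccc(O)cc2)c2c1C=CC(C)(C)O2`) has not yet been measured. It carries 4-hydroxyphenyl in place of 3-chlorophenyl on a double-bonded chain carbon bound to a double-bonded chain carbon.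

Going by the values given here, no measured step involves 4-hydroxyphenyl, so the nearest guides are the steps into compound 3. Chloro in place of nitro gave an at least 3.5-fold higher number from compound 1 to compound 3 (0.54 log units; beyond the scatter) as its step, while 3-chlorophenyl in place of pyridin-2-yl gave an at least 1.7-fold higher number from compound 2 to compound 3 (0.23 log units; that floor lies within the scatter) as its step. The two compounds with actual numbers stand apart by a 2.0-fold higher number from compound 1 to compound 2 (0.31 log units; beyond the scatter) in this comparison. Leaving 3-chlorophenyl behind is therefore expected to bring a modest move toward a lower number in this assay rather than a large one. The expected change is an at least 1.6-fold lower number from compound 3 to compound 4 (0.22 log units; that floor lies within the scatter) on this estimate. Compound 4 is estimated at 6000 nM with an expected range from 2000 nM to 18000 nM as its span.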

Compound 4, half-maximal inhibitory concentration: > 10000 nM
Compound 4: a limit, no number (the forecaster's own chance of this, stated with the estimate: 30%); middle value at least 1.6-fold (0.22 log units) away from the limit.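

In this assay compound 3 and compound 4 both read as a limit and not a number, so the step between them cannot be read: the limit of > 10000 nM in this assay, at which 2 of the 4 values shown sit. At this position, 4-hydroxyphenyl in place of pyridin-2-yl gives an at least 1.7-fold higher number from compound 2 to compound 4 (0.23 log units; that floor lies within the scatter) and 4-hydroxyphenyl in place of 3-nitrophenyl gives an at least 3.5-fold higher number from compound 1 to compound 4 (0.54 log units; beyond the scatter). Going by these compounds alone, the new step from compound 1 is beyond the scatter, while the floor of the step from compound 2 is not, and 4-hydroxyphenyl, the only group here with a hydrogen-bond donor, brings no measurable number.

As far as these compounds go, how far compound 3 and compound 4 lie past the limit remains open. Also open, from the compounds shown here alone, is whether 3-hydroxyphenyl or 4-aminophenyl at this place would give a measurable number.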